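Terminal group replacement on the anilide series

The source may report more compounds than this note shows. Statements on the series, on what has been measured and on what is new or still open speak of the compounds shown alone.

Within the data shown here, compound 1 `N=C(N)c1cccc(OCC(=O)Nc2ccc(C(=O)N3CCC3)cc2)c1` is the only member of the series with a defined number in an assay on isolated protein for inhibition of serine protease 1 (Homo sapiens); a higher number here means a weaker inhibitor, a lower number a stronger inhibitor: compound 1 gives 2050 nM. Compound 2 `N=C(N)c1cccc(OCC(=O)Nc2ccc(C(=O)N3CCOCC3)cc2)c1` reaches only the limit of the assay in this assay, where compound 2 gives > 10000 nM. Among the measured compounds shown here, the single measured step, an at least 4.8-fold higher number from compound 1 to compound 2 (0.68 log units; beyond the scatter), shows that exchanging the ring on the terminal carbonyl carbon weakens inhibition, its full size being bounded by the limit of > 10000 nM in this assay, at which 1 of the 2 values shown sits. Compound 3 `N=C(N)c1cccc(OCC(=O)Nc2ccc(-c3ccccc3S(N)(=O)=O)cc2)c1` replaces the whole carbonyl-linked group with an aryl sulfonamide: 2-sulfamoylphenyl in place of (azetidin-1-yl)carbonyl on an aromatic carbon. The step from compound 1 to compound 2 bears on this change only in that it touches the same position, and it ran toward weaker inhibition; the change in compound 3 is far larger, so the direction is uncertain and no step beyond the scatter is firmly expected. Compound 3 is expected to give 3000 nM, within 700 nM to 15000 nM in this assay. The expected step is a 1.5-fold higher number from compound 1 to compound 3 (0.17 log units; within the scatter).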

Compound 3, half-maximal inhibitory concentration: 3370 nM
Compound 3: middle estimate off by 1.1-fold (0.05 log units), on the low side; the range from low to high includes it.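

In this assay, the position tolerates more than the earlier ring exchange on the carbonyl suggested: with 2-sulfamoylphenyl in place of (azetidin-1-yl)carbonyl, the step is a 1.6-fold higher number from compound 1 to compound 3 (0.22 log units; within the scatter), so a carbonyl-linked ring is not needed to stay at the level of compound 1. The same group in place of (morpholin-4-yl)carbonyl gives an at least 2.9-fold lower number from compound 2 to compound 3 (0.47 log units; beyond the scatter), which ties the loss in compound 2 to the morpholin-4-yl group rather than to every change at this position. Compound 2 stands at a limit of the assay, so this step has a lower bound only: the limit of > 10000 nM in this assay, at which 1 of the 3 values shown sits.

The share of the sulfonamide cannot be separated from that of the added aromatic ring without a plain phenyl at this position. From the compounds shown here alone, whether a pyrrolidin-1-yl or piperidin-1-yl amide sides with compound 1 or compound 2 also remains open.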